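Changing the group on sulfur: compound 2 to compound 3

This account rests on a few compounds, and the source may have more. Where it says the series, first, only, none or still open, it means among the compounds named here.

In a functional assay on MGC-803 cells (Homo sapiens) for inhibition, read by MTT assay, with a stated time of 72 h (on this read-out higher numbers stand for weaker inhibition and lower numbers for stronger inhibition), compound 1 (`CN1CCN(c2cc(C(F)(F)F)nc(SCc3ccc(C(F)(F)F)cc3)n2)CC1`) gives 15800 nM. For the measured compounds named here, compound 2 (`FC(F)(F)c1ccc(CSc2nc(Sc3nnnn3-c3ccccc3)cc(C(F)(F)F)n2)cc1`) gives 12400 nM, and this number lies within the scatter of the one for compound 1, so neither compound stands apart on the two values available. Compound 3 (`FC(F)(F)c1ccc(CSc2nc(SC3=NCCS3)cc(C(F)(F)F)n2)cc1`) keeps the shared core of compound 2 and changes only the group on a sulfur whose other neighbour is an aromatic carbon: a group of 5 heavy atoms (3 carbon, 1 nitrogen, 1 sulfur; one five-membered non-aromatic ring with 2 hetero atoms) in place of a group of 11 heavy atoms (7 carbon, 4 nitrogen; one five-membered aromatic ring with 4 hetero atoms, one six-membered aromatic ring of carbon only), on a sulfur. Going by the values given here, no measured step shows this change, so the expectation in this assay rests only on compound 2 at 12400 nM and carries wide uncertainty. The estimated step, a 1.0-fold higher number from compound 2 to compound 3 (0.02 log units; within the scatter), is expected to stay within the scatter, with no direction favoured. For compound 3 the expected value is 13000 nM, with an estimated range of 5000 nM to 30000 nM.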

Compound 3, half-maximal inhibitory concentration: 24500 nM
Compound 3: the middle estimate sits 1.9-fold (0.28 log units) below what was measured; low and high end bracket the measured number.
By their numbers in this assay, from the lowest: compounds 2, 1 and 3 (each within the scatter of the next).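

In this assay, a group of 5 heavy atoms with one five-membered non-aromatic ring in place of 1-phenyl-1H-tetrazol-5-yl, on a sulfur whose other neighbour is an aromatic carbon, gives a step that stays within the scatter (a 2.0-fold higher number from compound 2 to compound 3 (0.30 log units; within the scatter)). Both aromatic rings of the departing group can therefore go without a step beyond the scatter. The step on an aromatic carbon (a 1.6-fold higher number from compound 1 to compound 3 (0.19 log units; within the scatter)) is also within the scatter, so this read-out does not separate the three groups, and no supporting data bear on a cause.

Open, on these data alone, is whether any group at this place gives a step beyond the scatter, for example a carboxylic acid on a short chain or a primary amine. A much smaller group, such as methyl on the sulfur, also remains to be placed against these values.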